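The compounds below may be only part of what the source reports. "The series", "measured", "known", "first", "only" and "open" are said of these compounds alone.

Compound 2, `CS(=O)(=O)c1cccc(C#Cc2cc(Cl)ccc2OCC(=O)O)c1`, gives the lower of the two numbers in an assay on CHO cells for displacement of a labelled ligand from prostaglandin D2 receptor 2 (Homo sapiens), read by scintillation counting (on this read-out lower numbers stand for stronger inhibition and higher numbers for weaker inhibition), at 15 nM. Compound 1, `CS(=O)(=O)Cc1cccc(C#Cc2cc(Cl)ccc2OCC(=O)O)c1`, gives 48 nM in this assay. Among the compounds with values here, the one measured step is a 3.2-fold lower number from compound 1 to compound 2 (0.51 log units; beyond the scatter). Compound 3, `Cc1ccc(S(C)(=O)=O)cc1C#Cc1cc(Cl)ccc1OCC(=O)O`, differs from compound 2 by methyl in place of hydrogen on an aromatic carbon. Within the data shown here, no measured pair shows this kind of change, and the only known step concerns a different group, so it gives no guide to the size or direction of this one. Without such a guide, no step beyond the scatter is expected. For compound 3 the estimate is 15 nM, between 5 nM and 45 nM, which amounts to no change at the digits printed from compound 2 to compound 3 (within the scatter).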

Compound 3, inhibition constant: 5 nM
Estimate against measurement, compound 3: 3.0-fold (0.48 log units) above; the range from low to high includes it.
By their numbers in this assay, from the lowest: compound 3; then compound 2; then compound 1.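

Putting a methyl on this aromatic carbon, ortho to a large group and para to a methylsulfonyl group, gives a 3.0-fold lower number from compound 2 to compound 3 (0.48 log units; beyond the scatter) in this assay. This carbon therefore responds to substitution: a group of one heavy atom in place of hydrogen is enough to move the number beyond the scatter, in the direction of stronger inhibition. No measurement shown accounts for this step. The compounds shown leave open whether an ethyl group, a chlorine atom or a methoxy group on this carbon would act like methyl. They also leave open whether methyl would give a similar step on compound 1.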